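Three Compounds at the Assay Limit, a Fourth Awaited

The compounds below may be only part of what the source reports. "The series", "measured", "known", "first", "only" and "open" are said of these compounds alone.

Compound 1 `COc1cc(C2CC(c3ccccc3)=NN2c2ccc(-c3ccccc3)nn2)cc(OC)c1OC`, compound 2 `COc1ccc(C2CC(c3ccc(Cl)cc3)=NN2c2ccc(-c3ccccc3)nn2)cc1` and compound 3 `COc1ccc(C2CC(c3ccc(Cl)cc3)=NN2c2ccc(-c3ccccc3)nn2)c(OC)c1` share one core and were all tested in a functional assay on Caco-2 cells (Homo sapiens) for antiproliferative activity, read by MTT assay, with a stated time of 24 h; on this read-out higher numbers stand for weaker inhibition and lower numbers for stronger inhibition. For compound 1 the result is only a limit of the assay, > 100000 nM, not a number. Compound 2 likewise reaches only the limit > 100000 nM. Compound 3 too gives only the limit > 100000 nM. The step that the two limits leave unreadable from compound 2 to compound 3 cannot be read in size because the limit of > 100000 nM in this assay, at which 3 of the 3 values shown sit, covers both ends of it. Compound 3 thus stands where every measured compound stands, at the limit, with nothing to set it apart.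

Compound 4 `COc1cc(C2CC(c3ccc(Cl)cc3)=NN2c2ccc(-c3ccccc3)nn2)cc(OC)c1OC` has not yet been measured. It differs from compound 3 by 3,4,5-trimethoxyphenyl in place of 2,4-dimethoxyphenyl on a saturated ring carbon. For the measured compounds named here, no measured step bears directly on this change, though compound 1 already carries the 3,4,5-trimethoxyphenyl group and also sits at the limit. The expected step that the limit leaves unreadable from compound 3 to compound 4 is therefore none that could be read. Compound 4 is expected to give 150000 nM, within 40000 nM to 1000000 nM, most likely reported again only as a limit.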

Compound 4, half-maximal inhibitory concentration: > 100000 nM
Compound 4 gave a limit, no number; the forecaster's own chance of this, stated with the estimate: 85%; the middle value is on the limit's open side.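

For the compounds shown here, no step between compound 1, compound 2, compound 3 and compound 4 can be read in size, because all four compounds stop at the same assay limit rather than giving a number: the limit of > 100000 nM in this assay, at which 4 of the 4 values shown sit.

The compounds shown leave open whether the chloro group or the change from 2,4-dimethoxyphenyl to 3,4,5-trimethoxyphenyl alters activity at all.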